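Swapping a phenyl for a methyl on a saturated ring carbon

The source may hold more compounds than are shown below. What is called first, only, known or untested is meant among the compounds shown, and "the series" means these compounds.

Measured compounds:
- compound 1, `C=C(C)C(=O)c1ccc(OC)cc1OC`, 23.7%
- compound 2, `CCOC(=O)c1nn(-c2ccccc2)c(-c2ccc(OC)cc2OC)c1C`, 4.9%
- compound 3, `COc1ccc(C2=NN(C(=O)NS(=O)(=O)c3ccc(Cl)cc3)CC2c2ccccc2)c(OC)c1`, 24.2%

All three were tested in a functional assay on the whole organism (strain albino) for inhibition, with Rattus norvegicus as the target, read by paw edema, with stated times of 30 min and 1 h, at a dose of 25 mg/kg by the intraperitoneal route; a higher number here means more inhibition at the dose given (going by the name of the read-out), a lower number less inhibition. Compound 3 gives the largest of the three numbers, but the number for compound 1 lies within the usual scatter of repeated measurements, so these two cannot be told apart. The number for compound 2 lies beyond the scatter, lower than that of compound 3.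

Compound 4, `COc1ccc(C2=NN(C(=O)NS(=O)(=O)c3ccc(Cl)cc3)CC2C)c(OC)c1`, has not yet been measured in this assay. It differs from compound 3 in one place: methyl in place of phenyl on a saturated ring carbon.

Among the compounds with values here, no pair of measured compounds differs in exactly this way, so there is no measured step to lean on. The expectation is a small drop, or none beyond the scatter: the step from compound 3 to compound 4 is estimated at a number 6.2 percentage points lower from compound 3 to compound 4 (within the scatter). For compound 4 the estimated value in this assay is 18%, with a likely range from 5% to 32%.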

Compound 4, a percentage reported as inhibition, in the whole organism at one dose (the size of the read-out at that dose, not a potency): 12.3%
For compound 4 the middle estimate is 5.7 percentage points above the measured one; low and high end bracket the measured number.
By their numbers in this assay, from the lowest: compounds 2 and 4 (each within the scatter of the next); then compounds 1 and 3 (each within the scatter of the next).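

In this assay, this saturated ring carbon is not indifferent to what it carries: methyl in place of phenyl gives a number 11.9 percentage points lower from compound 3 to compound 4 (beyond the scatter). Within the data shown here, this is the first step here that isolates one place on the shared core, as the earlier compounds offered no such pair, and it shows that the phenyl group contributes to the inhibition seen at this dose. The finding rests on a single pair, and no measurement at hand bears on the reason for the step.

As far as these compounds go, it remains open whether the phenyl ring itself is needed, or whether an ethyl chain or a cyclohexyl ring on the same carbon would serve as well. Also open, from the compounds shown here alone, is how a benzyl group, or plain hydrogen, would fare at this position.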